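A few compounds are considered here, and "the series" means these few. Any claim that something is new, unique, unknown or untested is made for them only; others in the source may bear on it.

Of the compounds shown here, two have so far been measured in an assay on isolated protein for antagonist activity at Voltage-dependent L-type calcium channel subunit alpha-1C (Cavia porcellus), with a stated time of 15 min; a lower number here means a stronger inhibitor, a higher number a weaker inhibitor. Compound 2 `CCOC(=O)C1=C(C)NC(C)=C(C(=O)OC)C1c1csc(-c2ccc(Cl)cc2)n1` gives 22000 nM, the highest of the two numbers. Compound 1 `CCCOC(=O)C1=C(C)NC(C)=C(C(=O)OCCC)C1c1csc(-c2ccc(Cl)cc2)n1` gives 4800 nM, a lower number that lies beyond the usual scatter. Compound 3 `CCCOC(=O)C1=C(C)NC(C)=C(C(=O)OCC)C1c1csc(-c2ccc(Cl)cc2)n1` has not been measured; it differs from compound 2 by ethyl in place of hydrogen on a saturated chain carbon bound to an oxygen next to a carbonyl group. Since compound 1, with the longer chain on both ester groups, gives 4800 nM against compound 2 at 22000 nM, lengthening one chain is expected to lower the number. The step from compound 2 to compound 3 is therefore expected to be a 2.8-fold lower number from compound 2 to compound 3 (0.44 log units; beyond the scatter). Compound 3 is estimated at 8000 nM, within 3000 nM to 20000 nM.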

Compound 3, half-maximal inhibitory concentration: 4090 nM
Estimate against measurement, compound 3: 2.0-fold (0.29 log units) above; low and high end bracket the measured number.
By their numbers in this assay, from the lowest: compounds 3 and 1 (each within the scatter of the next); then compound 2.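

Methoxy to propoxy alone gives a 5.4-fold lower number from compound 2 to compound 3 (0.73 log units; beyond the scatter) in this assay, so a single ester chain can account for a clear change. Hydrogen in place of methyl on a saturated chain carbon, two bonds along the chain from an oxygen next to a carbonyl group, gives a 1.2-fold lower number from compound 1 to compound 3 (0.07 log units; within the scatter), so that carbon makes no readable difference here. No measurement available explains either step.

As far as these compounds go, whether a butyl chain, a branched isopropyl chain or a chain ending in an amine would shift the number remains open.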